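Replacing fluoro with methyl: compound 2 to compound 3

The source may report more compounds than this note shows. Statements on the series, on what has been measured and on what is new or still open speak of the compounds shown alone.

In a functional assay on MDA-MB-231 cells (Homo sapiens) for cytotoxicity, read by MTT assay, with a stated time of 24 h (a higher number here means a weaker inhibitor, a lower number a stronger inhibitor), compound 1 (`NCC(=O)NCc1nnc(-c2ccc(F)cc2)o1`) gives 254 nM and compound 2 (`C[C@@H](N)C(=O)NCc1nnc(-c2ccc(F)cc2)o1`) gives 247 nM. For the measured compounds named here, compound 2 therefore stands level with compound 1 within the scatter, and these two values are the only measurements so far in this assay.

Compound 3 (`Cc1ccc(-c2nnc(CNC(=O)[C@@H](C)N)o2)cc1`) keeps the chain of compound 2 and differs in one place: methyl in place of fluoro on an aromatic carbon. This is methyl in place of fluoro on an aromatic carbon, para to a large group.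

Going by the values given here, the only measured step is a 1.0-fold lower number from compound 1 to compound 2 (0.01 log units; within the scatter), which lies within the scatter. That step is a methyl in place of hydrogen on a saturated chain carbon, so it bears only loosely on the new change. Among the compounds with values here, no measured step covers a change on the aromatic carbon, which leaves the direction open and the range wide.

No step beyond the scatter is expected in this assay. The estimated step is a 1.0-fold higher number from compound 2 to compound 3 (0.01 log units; within the scatter). For compound 3 the expected value is 250 nM, with an estimated range from 100 nM to 600 nM.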

Compound 3, half-maximal inhibitory concentration: 254 nM
Compound 3: middle estimate off by 1.0-fold (0.01 log units), on the low side; the range from low to high includes it.
By their numbers in this assay, from the lowest: compounds 2, 1 and 3 (each within the scatter of the next).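

In this assay the swap at the aromatic carbon gives a 1.0-fold higher number from compound 2 to compound 3 (0.01 log units; within the scatter) and so places methyl and fluoro level at this position, para to a large group. The earlier pair spoke only to the saturated chain carbon through a 1.0-fold lower number from compound 1 to compound 2 (0.01 log units; within the scatter) and said nothing about the aromatic ring, so the series now has one step in each of these two places, both within the scatter. Nothing at hand explains why the number for compound 3 stands level with that of compound 2.

The methyl and fluoro groups, with one heavy atom each, say little about larger or differently built groups on this aromatic carbon, so a methoxy, a trifluoromethyl, a nitrile or a carboxylic acid there could still read differently, as could plain hydrogen. On the chain side, a longer chain in place of the methyl on the saturated carbon, or a substituted amine in place of the free amine, also remains an open question for this series.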